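The source may hold more compounds than are shown below. What is called first, only, known or untested is meant among the compounds shown, and "the series" means these compounds.

Measured in a functional assay with Oryctolagus cuniculus as the target; a lower number here means a stronger inhibitor, a higher number a weaker inhibitor:
- Compound 1 `CNC(=N)Nc1nc(-c2ccc(OC)cc2)c(-c2ccc(OC)cc2)s1`: 62 nM
- Compound 2 `COc1ccc(-c2nc(CNC(=O)CSc3ccccc3)sc2-c2ccc(OC)cc2)cc1`: < 100 nM (a limit)
- Compound 3 `COc1ccc(-c2nc(CNC(=O)CSC)sc2-c2ccc(OC)cc2)cc1`: < 100 nM (a limit)

Compound 3 stands only at a limit, < 100 nM, and has no number of its own. Compound 2 shares that limit, so the evidence here is the limit of < 100 nM in this assay, at which 2 of the 3 values shown sit. Among the measured compounds shown here, the one true number among the three belongs to compound 1.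

Compound 4 `COc1ccc(-c2nc(CNC(=O)NC(C)C)sc2-c2ccc(OC)cc2)cc1` differs from compound 3 in one place: isopropylamino in place of (methylsulfanyl)methyl on a carbonyl carbon. Isopropylamino stands in place of (methylsulfanyl)methyl on a carbonyl carbon.

For the measured compounds named here, two measured steps bear on this change. One is a step that the two limits leave unreadable from compound 2 to compound 3, with methyl in place of phenyl on a sulfur. The other is a step that the limit leaves unreadable from compound 1 to compound 3. Neither has a readable size, so neither offers a direction, and no step beyond the usual scatter is expected in this assay. The estimated step is a step that the limit leaves unreadable from compound 3 to compound 4.

For compound 4 the expected value is 50 nM, with an estimated range from 12 nM to 200 nM.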

Compound 4, half-maximal inhibitory concentration: 42 nM
Beside the measured number, compound 4's estimate is 1.2-fold (0.08 log units) above it; low and high end bracket the measured number.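

In this assay, compound 4 gives the side chain ((isopropylcarbamoyl)amino)methyl a true number at this position, where compound 2 and compound 3 hold only limits. Set against the guanidine-type group of compound 1, the change is a 1.5-fold lower number from compound 1 to compound 4 (0.17 log units; within the scatter), so the two groups on this aromatic carbon are not told apart in this assay. The steps to compound 4 from compound 2 and from compound 3 cannot be read, because both of those compounds stand at a limit: the limit of < 100 nM in this assay, at which 2 of the 4 values shown sit.

On these data alone, whether isopropylamino truly differs from (methylsulfanyl)methyl on the carbonyl carbon therefore stays open. Also open, as far as these compounds go, is what a smaller methylamino, a ring-bearing cyclohexylamino or a chain ending in a carboxylic acid would give on that same carbon in this assay.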